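This account rests on a few compounds, and the source may have more. Where it says the series, first, only, none or still open, it means among the compounds named here.

The series shares one core, seen in compound 1 `COc1ccc(-c2nc(C)oc2C(=O)N2CCN(c3cccc(Cl)c3)CC2)cc1`, compound 2 `Cc1nc(-c2ccccc2F)c(C(=O)N2CCN(c3cccc(Cl)c3)CC2)o1` and compound 3 `Cc1nc(-c2cccc(O)c2)c(C(=O)N2CCN(c3cccc(Cl)c3)CC2)o1`. In a functional assay on HL-60 cells (Homo sapiens) for inhibition, read by MTT assay, with a stated time of 72 h (a lower number here means a stronger inhibitor, a higher number a weaker inhibitor), compound 1 is recorded as "not active" (no number reported) without a number. In this assay compound 2 gives 39.4 nM, and compound 3 gives 105 nM. Going by the values given here, the only single-point step among the numbers is a 2.7-fold higher number from compound 2 to compound 3 (0.43 log units; beyond the scatter), and it leaves compound 3 with the higher of the two reported numbers, compound 2 being the nearest neighbour.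

Compound 4 `Cc1nc(-c2cccc(OP(=O)(O)O)c2)c(C(=O)N2CCN(c3cccc(Cl)c3)CC2)o1` is built from compound 3 by a group of 4 heavy atoms (3 oxygen, 1 phosphorus; no ring) in place of a hydrogen atom, on an oxygen on an aromatic ring. Among the compounds with values here, no measured step changes this oxygen; the one step on record, a 2.7-fold higher number from compound 2 to compound 3 (0.43 log units; beyond the scatter), alters the aromatic substituent itself and is modest in size, so it bears on compound 4 only loosely, as a sign that changes in this part of the molecule have so far moved this assay by modest amounts. On that basis the step is expected to be small, toward a higher number if anything, with a real chance of none beyond the scatter, giving an estimated 2.1-fold higher number from compound 3 to compound 4 (0.32 log units; beyond the scatter). Compound 4 is therefore expected to give about 220 nM in this assay, within a range of 60 nM to 800 nM.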

Compound 4, half-maximal inhibitory concentration: > 1000 nM
Compound 4: no number, only a limit (the forecaster's own chance of this, stated with the estimate: 15%); middle value at least 4.5-fold (0.65 log units) away from the limit.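

Going by these compounds alone, the replacement of the hydrogen atom on the oxygen of compound 3 by a group of 4 heavy atoms (3 oxygen, 1 phosphorus; no ring) is the first change on record at this oxygen, and it gives an at least 9.5-fold higher number from compound 3 to compound 4 (0.97 log units; beyond the scatter) in this assay. In this assay compound 4 has no single number, only a limit: the limit of > 1000 nM in this assay, at which 1 of the 4 values shown sits. Even as a limit, this step is larger than the one earlier step among the numbers, a 2.7-fold higher number from compound 2 to compound 3 (0.43 log units; beyond the scatter), so the oxygen on the aromatic ring is shown to be a place where a change can move the result further than the earlier compounds indicated.

Going by these compounds, how far compound 4 lies past its limit stays open, so the full size of the step is unknown. The compounds shown also leave open whether a methyl or an acetyl group on this oxygen, or an amine in place of the hydroxyl of compound 3, would shift the number as far as this group of 4 heavy atoms does.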